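This account rests on a few compounds, and the source may have more. Where it says the series, first, only, none or still open, it means among the compounds named here.

The first compound, compound 1 `COc1ccc(N(C)c2ccnc(Cl)n2)cc1`, is tested in a functional assay on HCT-116 cells (Homo sapiens) for antiproliferative activity, read by MTT assay, with a stated time of 48 h (a lower number here means a stronger inhibitor, a higher number a weaker inhibitor), and gives 1460 nM. Compound 2 `COc1ccc(N(C)c2ccnc(Cl)n2)cc1F` differs from it by fluoro in place of hydrogen on an aromatic carbon, and in this assay compound 2 gives 914 nM. That change made a 1.6-fold lower number from compound 1 to compound 2 (0.20 log units; within the scatter).

Compound 3 `COc1ccc(N(C)c2cc(C)nc(C)n2)cc1` has a different core; the difference between the two cores is not broken down here. In this assay compound 3 gives 1320 nM, and its value and that of compound 1 are within the scatter of each other.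

Compound 4 `COc1ccc(N(C)c2cc(C)nc(C)n2)cc1F` stands to compound 3 as compound 2 stands to compound 1: it carries fluoro in place of hydrogen on an aromatic carbon. The place is described in nearly the same words for both pairs, except that in the first pair it is meta to a group of 9 heavy atoms and in the second meta to a large group, so the change is of the same kind rather than the same. Since compound 3 starts at 1320 nM, the expectation for compound 4 in this assay is a step of about a 1.6-fold lower number from compound 3 to compound 4 (0.19 log units; within the scatter), resting on a 1.6-fold lower number from compound 1 to compound 2 (0.20 log units; within the scatter), which was within the scatter. Compound 4 is therefore estimated at 850 nM, expected to lie between 400 nM and 1800 nM.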

Compound 4, half-maximal inhibitory concentration: 584 nM
For compound 4 the middle estimate is 1.5-fold (0.16 log units) above the measured one; measured number inside the range.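

In this assay, fluoro in place of hydrogen on an aromatic carbon, ortho to a methoxy group, gives a 2.3-fold lower number from compound 3 to compound 4 (0.35 log units; beyond the scatter), a modest step. Both steps on the two cores point to a lower number, and the gap between them does not set them apart: the same change on two cores in this assay, a 1.6-fold lower number (0.20 log units; within the scatter) from compound 1 to compound 2 and a 2.3-fold lower number (0.35 log units; beyond the scatter) from compound 3 to compound 4, 1.4-fold (0.15 log units) apart, within the scatter of two such steps

This shows that, for these two pairs, the change carries from the core of compound 1 to the core of compound 3 with no difference that can be told from the scatter; it does not show that the core of compound 3 responds more strongly, that the step would hold on any further core, or why the number falls.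

The compounds shown leave open what an amine or a hydroxyl group would give at the same place on the aromatic ring. They also leave open how a longer chain in place of the methoxy group would behave on either core, with or without the fluoro.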